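This account rests on a few compounds, and the source may have more. Where it says the series, first, only, none or still open, it means among the compounds named here.

Compound 1 `COc1cc2c(Nc3ccc(F)c(Cl)c3F)ncnc2c(OC)c1OC` gives > 30000 nM in a functional assay on SGC-7901 cells (Homo sapiens) for antiproliferative activity, read by MTT assay, with a stated time of 72 h (on this read-out higher numbers stand for weaker inhibition and lower numbers for stronger inhibition), which is a limit of the assay.
Compound 2 `COc1cc2c(Nc3cccc(F)c3F)ncnc2c(OC)c1OC` gives > 30000 nM in this assay, a limit.
Compound 3 `COc1cc2c(Nc3cccc(Br)c3F)ncnc2c(OC)c1OC` gives > 30000 nM in this assay, a limit.

Compound 2 therefore stands only at a limit, and so do the two other values shown. For the measured compounds named here, the one step between measured compounds, a step that the two limits leave unreadable from compound 2 to compound 3, cannot be read, and the only evidence is the limit of > 30000 nM in this assay, at which 3 of the 3 values shown sit. Compound 4 `COc1cc2c(Nc3cc(F)ccc3Br)ncnc2c(OC)c1OC` differs from compound 2 by 2-bromo-5-fluorophenyl in place of 2,3-difluorophenyl on a nitrogen on an aromatic ring. Going by the values given here, with every measured value sitting at the limit, no step of known size bears on this change, and compound 4 is expected most likely to stay at the limit as well; the estimate is 40000 nM with a range from 8000 nM to 200000 nM. The expected step is a step that the limit leaves unreadable from compound 2 to compound 4, not distinguishable from none.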

Compound 4, half-maximal inhibitory concentration: 18400 nM
For compound 4 the middle estimate is 2.2-fold (0.34 log units) above the measured one; low and high end bracket the measured number.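

Among the compounds shown, only compound 4 reads as a number in this assay rather than a limit: the limit of > 30000 nM in this assay, at which 3 of the 4 values shown sit.

Placing 2-bromo-5-fluorophenyl in place of 2,3-difluorophenyl on a nitrogen on an aromatic ring gives an at least 1.6-fold lower number from compound 2 to compound 4 (0.21 log units; that floor lies within the scatter), and placing it in place of 3-bromo-2-fluorophenyl gives an at least 1.6-fold lower number from compound 3 to compound 4 (0.21 log units; that floor lies within the scatter). These are floors, so the true steps may be larger, but neither is yet shown to exceed the scatter.

Going by these compounds, it remains open how the number would move with chloro in place of the bromo of compound 4. On these data alone, whether an amine or a longer alkoxy chain on the shared core would shift it also remains open.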